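Thiophen-2-yl for furan-3-yl: working notes on the series

The source may hold more compounds than are shown below. What is called first, only, known or untested is meant among the compounds shown, and "the series" means these compounds.

Measured in a functional assay on K562 cells (Homo sapiens), read by MTT assay, with a stated time of 72 h (on this read-out lower numbers stand for stronger inhibition and higher numbers for weaker inhibition), so far

- compound 1 `COc1ncnc2c1c(-c1ccccc1)cn2[C@@H]1O[C@H](CO)[C@@H](O)[C@H]1O` gives > 20000 nM (a limit)
- compound 2 `CSc1ncnc2c1c(-c1ccoc1)cn2[C@@H]1O[C@H](CO)[C@@H](O)[C@H]1O` gives 60 nM (a number)

For the measured compounds named here, compound 2 carries the only true number so far. The reading for compound 1 is a limit (the limit of > 20000 nM in this assay, at which 1 of the 2 values shown sits) and not a number.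

Compound 3 (`CSc1ncnc2c1c(-c1cccs1)cn2[C@@H]1O[C@H](CO)[C@@H](O)[C@H]1O`) differs from compound 2 by thiophen-2-yl in place of furan-3-yl on an aromatic carbon. Both groups are five-membered aromatic rings with 1 hetero atom. Going by the values given here, no measured pair differs in one place only, so the size of this change has no direct precedent here. A modest step toward weaker inhibition is expected, though a result within the scatter would be no surprise. The estimated step (a 2.5-fold higher number from compound 2 to compound 3 (0.40 log units; beyond the scatter)) is therefore kept small. Compound 3 is estimated at 150 nM with 30 nM to 1500 nM as the expected range.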

Compound 3, half-maximal inhibitory concentration: 11600 nM
For compound 3 the middle estimate is 77-fold (1.89 log units) below the measured one; the measured number lies above the stated range.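

In this assay this position proves highly sensitive: thiophen-2-yl in place of furan-3-yl gives a 190-fold higher number from compound 2 to compound 3 (2.29 log units; beyond the scatter), although both groups are five-membered aromatic rings with 1 hetero atom and the same heavy-atom count. For the compounds shown here, this is the first step that differs in one place, so it shows that the group on this aromatic carbon matters on its own, with the rest of the structure unchanged. Nothing measured here accounts for the size of this step.

The compounds shown do not separate the change of hetero atom from the change in ring attachment, since neither thiophen-3-yl nor furan-2-yl stands among them. From the compounds shown here alone, how an amine or a longer alkyl chain on this carbon would read also remains open.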